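Ethyl ester in place of the acid on a pyrazole series

The source may report more compounds than this note shows. Statements on the series, on what has been measured and on what is new or still open speak of the compounds shown alone.

Of the compounds shown here, three sharing one core have been tested in a functional assay on Maver1 cells (Homo sapiens) for inhibition, read by luminescence and CellTiter-Glo, with a stated time of 72 h; a lower number here means a stronger inhibitor, a higher number a weaker inhibitor. Compound 1 `O=C(CCl)N1CCCC(n2nc(-c3ccc(Oc4ccccc4)cc3)cc2CO)C1` gives 1100 nM. Compound 2 `C/C=C/C(=O)Nc1cccc(Cn2nc(-c3ccc(Oc4ccccc4)cc3)cc2C(=O)O)c1` gives 31600 nM, the highest number of the three, and compound 3 `C/C=C/C(=O)N1CCCC(n2nc(-c3ccc(Oc4ccccc4)cc3)cc2C(=O)OCC)C1` gives 19600 nM. The gap between compound 2 and compound 3 is within the usual scatter, so these two cannot be ranked against each other, whereas compound 1 sits well beyond the scatter from compound 2.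

Compound 4 `C/C=C/C(=O)Nc1cccc(Cn2nc(-c3ccc(Oc4ccccc4)cc3)cc2C(=O)OCC)c1` has not yet been measured. It differs from compound 2 in one place: ethyl in place of hydrogen on an oxygen next to a carbonyl group. Going by the values given here, no pair of measured compounds differs by this change alone, so its size cannot be read off directly. Compound 3 carries the same ethoxycarbonyl group, and compound 3 gives a number in this assay that is within the scatter of compound 2, which gives no basis for expecting a large move in either direction.

The step from compound 2 to compound 4 is therefore expected to be small, a 2.1-fold lower number from compound 2 to compound 4 (0.32 log units; beyond the scatter), tending if anything toward a lower number. Compound 4 is estimated at 15000 nM in this assay, with a likely range from 4000 nM to 50000 nM.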

Compound 4, half-maximal inhibitory concentration: 14200 nM
Compound 4: middle estimate off by 1.1-fold (0.02 log units), on the high side, within the range that was stated.
By their numbers in this assay, from the lowest: compound 1; then compounds 4, 3 and 2 (each within the scatter of the next, the first and the last beyond it).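

Read on its own for the first time, the change of carboxy to ethoxycarbonyl gives in this assay a modest step, a 2.2-fold lower number from compound 2 to compound 4 (0.35 log units; beyond the scatter), which lies only a little beyond the usual scatter. Going by these compounds alone, earlier, the ethoxycarbonyl group could be seen only in compound 3, which also differs from the acid compound 2 elsewhere, so the effect of ethyl on this oxygen could not be separated from those other differences. This pair shows that the hydrogen of the carboxy group is not needed to hold the activity at this position, as replacing it with ethyl lowers the number rather than raising it, although nothing offered here accounts for the size of the step.

On these data alone, what remains open is whether a longer chain such as butyl on this oxygen, or an amine in place of the ethoxy group, would lower the number further or raise it. Within the data shown here, it is also open whether ethyl in place of hydrogen on this oxygen would give a similar step on the other side chain, the one carried by compound 3.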